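Aryl replacement on the shared core: a note before compound 4

The compounds below may be only part of what the source reports. "The series", "measured", "known", "first", "only" and "open" are said of these compounds alone.

Measured so far in a functional assay on the whole organism for inhibition, with Mus musculus as the target, at a dose of 25 mg/kg by the oral route; a higher number here means more inhibition at the dose given (going by the name of the read-out), a lower number less inhibition:
compound 1 `Fc1cccc(N2CCN(CCCOc3ccc4c(c3)CCC4)CC2)c1`: 19%
compound 2 `Clc1ccc(N2CCN(CCCCOc3ccc4c(c3)CCC4)CC2)cc1`: 31%
compound 3 `Clc1cc(Cl)cc(N2CCN(CCCCOc3ccc4c(c3)CCC4)CC2)c1`: 0%

Compound 1 stands second highest of the three numbers; compound 2 is higher and compound 3 lower, both beyond the scatter. For the measured compounds named here, the one measured step, a number 31 percentage points lower from compound 2 to compound 3 (beyond the scatter), swaps one substituted phenyl for another on the ring nitrogen, so a change of this kind can move the read-out strongly.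

Compound 4 `O=[N+]([O-])c1ccc(N2CCN(CCCOc3ccc4c(c3)CCC4)CC2)cc1` differs from compound 1 by 4-nitrophenyl in place of 3-fluorophenyl on an amine nitrogen in a ring. Going by the values given here, no measured step covers this particular swap, so its direction cannot be read from the data. The expected step is a number 4 percentage points lower from compound 1 to compound 4 (within the scatter), with wide uncertainty in both directions. Compound 4 is expected at 15%, within a range from 0% to 40%.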

Compound 4, a percentage reported as inhibition, in the whole organism at one dose (the size of the read-out at that dose, not a potency): 0%
For compound 4 the middle estimate is 15 percentage points above the measured one; low and high end bracket the measured number.
By their numbers in this assay, from the lowest: compounds 3 and 4 (each within the scatter of the next); then compound 1; then compound 2.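

In this assay, for the compounds shown here, the step is a number 19 percentage points lower from compound 1 to compound 4 (beyond the scatter) and it is the first measured change of the aryl group on the core of compound 1. It shows that this position, the amine nitrogen in a ring, is sensitive to the aryl group with this chain as well, and that 4-nitrophenyl does not retain the read-out of 3-fluorophenyl. No measurement at hand explains this drop.

Still open, from the compounds shown here alone, is how an amine or a carboxylic acid on the phenyl ring would read here, and whether 4-nitrophenyl behaves the same on a longer chain.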